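Adding a second fluoro to compound 2

The compounds below may be only part of what the source reports. "The series", "measured", "known", "first", "only" and "open" are said of these compounds alone.

Measured in a functional assay on MDA-MB-231 cells (Homo sapiens) for cytotoxicity, read by MTT assay, with a stated time of 72 h; a lower number here means a stronger inhibitor, a higher number a weaker inhibitor:
compound 1 `O=C(CN1CCN(c2nnc(Cc3ccccc3)c3ccccc23)CC1)Nc1ccc(F)c(C(F)(F)F)c1`: 760 nM
compound 2 `O=C(CN1CCN(c2nnc(Cc3ccncc3)c3ccccc23)CC1)Nc1cccc(F)c1`: 4.4 nM
compound 3 `O=C(CN1CCN(c2nnc(Cc3ccccc3)c3ccccc23)CC1)Nc1cccc(F)c1`: 3730 nM

Compound 2 has the lowest number of the three, and the other two stand far higher. Compound 4 `O=C(CN1CCN(c2nnc(Cc3ccncc3)c3ccccc23)CC1)Nc1ccc(F)c(F)c1` differs from it by fluoro in place of hydrogen on an aromatic carbon, turning 3-fluorophenyl into 3,4-difluorophenyl: fluoro in place of hydrogen on an aromatic carbon.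

For the measured compounds named here, only one measured step touches this group: a 4.9-fold higher number from compound 1 to compound 3 (0.69 log units; beyond the scatter). It is modest, and it is an imperfect guide, since its richer ring also carries trifluoromethyl and both of its compounds have phenyl, not the pyridin-4-yl group that compound 4 keeps. The other measured step, an 850-fold higher number from compound 2 to compound 3 (2.93 log units; beyond the scatter), is far larger, but it concerns that pyridin-4-yl group, which does not change here. As far as these compounds go, the small change therefore suggests no clear step in this assay, and the direction remains open. The expected step is a 1.4-fold higher number from compound 2 to compound 4 (0.13 log units; within the scatter), which would lie within the scatter. For compound 4 the estimated value is 6 nM, with an expected range of 1.2 nM to 50 nM.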

Compound 4, half-maximal inhibitory concentration: 0.84 nM
Compound 4: the middle estimate sits 7.1-fold (0.85 log units) above what was measured; measured number below the stated range.
By their numbers in this assay, from the lowest: compound 4; then compound 2; then compound 1; then compound 3.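

In this assay, the added fluoro gives a 5.2-fold lower number from compound 2 to compound 4 (0.72 log units; beyond the scatter), so this ring position still affects the read-out when pyridin-4-yl is present. For the compounds shown here, the only earlier step on this ring, a 4.9-fold higher number from compound 1 to compound 3 (0.69 log units; beyond the scatter), involved two compounds with phenyl and a richer ring that also carried trifluoromethyl. This result isolates one fluoro on an aromatic carbon, ortho to a fluoro group and para to a large group, and shows that this single change moves the number beyond the scatter, although no evidence here gives a reason for the step.

As far as these compounds go, whether chloro, methoxy or nitrile in the same place would move the number in the same direction remains open. So does whether fluoro would give a similar step in a compound with phenyl in place of pyridin-4-yl.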